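This account rests on a few compounds, and the source may have more. Where it says the series, first, only, none or still open, it means among the compounds named here.

Measured so far in a functional assay on A-375 cells (Homo sapiens) for antiproliferative activity, read by MTT assay, with a stated time of 72 h; a lower number here means a stronger inhibitor, a higher number a weaker inhibitor:
Compound 1 `O=C1COc2ccc(-c3cccc(NS(=O)(=O)c4ccc(F)cc4)c3)cc2N1c1ccccc1`: for compound 1 the result is a limit, > 40000 nM.
Compound 2 `O=C1COc2ccc(-c3cnc(Cl)c(NS(=O)(=O)c4ccc(F)cc4)c3)cc2N1c1ccccc1`: compound 2 gives 36900 nM.
Compound 3 `O=C1COc2ccc(-c3cccc(NS(=O)(=O)c4ccc(F)cc4)c3)cc2N1C1CC1`: for compound 3 the result is again a limit, > 40000 nM.

Going by the values given here, compound 2 thus holds the only number among the three; the other two results are limits. The change from compound 1 to compound 3, (cyclopropyl in place of phenyl on an amide-type nitrogen in a ring), produced a step that the two limits leave unreadable from compound 1 to compound 3, which stays unreadable because of the limit of > 40000 nM in this assay, at which 2 of the 3 values shown sit. How the core of compound 1 differs from that of compound 2 is not broken down here.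

Compound 4 `O=C1COc2ccc(-c3cnc(Cl)c(NS(=O)(=O)c4ccc(F)cc4)c3)cc2N1C1CC1` carries the same change relative to compound 2: cyclopropyl in place of phenyl on an amide-type nitrogen in a ring. Among the compounds with values here, since the only measured instance of this change is unreadable, the expectation for compound 4 rests on the value of compound 2, 36900 nM, and is an estimated step of a 1.1-fold higher number from compound 2 to compound 4 (0.04 log units; within the scatter). Compound 4 is therefore expected to sit near 40000 nM, within 15000 nM to 100000 nM.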

Compound 4, half-maximal inhibitory concentration: 21800 nM
Estimate against measurement, compound 4: 1.8-fold (0.26 log units) above; the range from low to high includes it.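

In this assay, cyclopropyl in place of phenyl gives a 1.7-fold lower number from compound 2 to compound 4 (0.23 log units; within the scatter), so compound 2 and compound 4 cannot be told apart on this core. The same change on the core of compound 1 cannot be read, and no comparison between the two cores is possible because compound 1 and compound 3 both sit at a limit: the limit of > 40000 nM in this assay, at which 2 of the 4 values shown sit. The series therefore offers one readable instance of this change, which does not show that its outcome carries from one core to another.

The compounds shown leave open what a methyl group, or a longer chain ending in an amine, would give on the amide-type nitrogen in a ring. They also leave open whether either group would behave alike on both cores.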